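The source may hold more compounds than are shown below. What is called first, only, known or untested is meant among the compounds shown, and "the series" means these compounds.

In a functional assay on MGC-803 cells (Homo sapiens) for inhibition, read by MTT assay, with a stated time of 48 h (a higher number here means a weaker inhibitor, a lower number a stronger inhibitor), compound 1 `COc1ccc(CN(C(=O)CCCl)c2cc(OC)c(OC)c(OC)c2)cc1O` gives 140 nM, the lowest of the two numbers in hand. Going by the values given here, compound 2 `C/C=C/C(=O)N(Cc1ccc(OC)c(Cl)c1)c1cc(OC)c(OC)c(OC)c1` gives 7100 nM in this assay; the gap between compound 1 and compound 2 lies beyond the scatter, but these two differ in more than one place, so no single step is read from them. Compound 3 `CCCCC(=O)N(Cc1ccc(OC)c(O)c1)c1cc(OC)c(OC)c(OC)c1` differs from compound 1 by ethyl in place of chloro on a saturated chain carbon, two bonds along the chain from a carbonyl carbon. Among the compounds with values here, no measured pair shows this change. For compound 3 the step of a 5.7-fold higher number from compound 1 to compound 3 (0.76 log units; beyond the scatter) is expected to run toward a weaker inhibitor, beyond the scatter. Compound 3 is estimated at 800 nM, within 200 nM to 4000 nM.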

Compound 3, half-maximal inhibitory concentration: 66 nM
For compound 3 the middle estimate is 12-fold (1.08 log units) above the measured one; measured number outside the range, below it.
By their numbers in this assay, from the lowest: compound 3; then compound 1; then compound 2.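

In this assay, the step of a 2.1-fold lower number from compound 1 to compound 3 (0.33 log units; beyond the scatter) shows that chloro is not required on this saturated chain carbon, two bonds along the chain from a carbonyl carbon: ethyl is tolerated there, and the number moves toward a stronger inhibitor. This modest step rests on a single pair. No measurement at hand bears on what lies behind it.

Going by these compounds, how a longer chain or an amine would read at this place remains open. So does whether the same change holds on any core other than that of compound 1.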